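A Fluoroindolyl Group in Place of the Dimethylbenzimidazolyl

The source may hold more compounds than are shown below. What is called first, only, known or untested is meant among the compounds shown, and "the series" means these compounds.

Compound 1, `O=c1[nH]c2ccccc2n1C/C=C/CN1CCN(C(c2ccccc2)c2ccccc2)CC1`: > 10000 nM, a limit of the assay.
Compound 2, `c1ccc(-c2nc3ccccc3n2CCCCN2CCN(C(c3ccccc3)c3ccccc3)CC2)cc1`: 1200 nM.
Compound 3, `Cc1cc2ncn(CCCCN3CCN(C(c4ccccc4)c4ccccc4)CC3)c2cc1C`: 770 nM.

In an assay on RPMI-8226 cells for antagonist activity at P2X purinoceptor 7 (Homo sapiens), read by calcium flux (a lower number here means a stronger inhibitor, a higher number a weaker inhibitor), compound 3 gives 770 nM, the lowest of the two numbers recorded. Compound 2 gives 1200 nM, which lies within the scatter of compound 3, so the two cannot be ordered. For compound 1 the assay reports only a limit, > 10000 nM; one of the three values sits at the limit of > 10000 nM in this assay, at which 1 of the 3 values shown sits.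

Compound 4, `Fc1cccc2c1ccn2CCCCN1CCN(C(c2ccccc2)c2ccccc2)CC1`, differs from compound 3 by 4-fluoro-1H-indol-1-yl in place of 5,6-dimethyl-1H-benzimidazol-1-yl on a saturated chain carbon, four bonds along the chain from an amine nitrogen in a ring. Within the data shown here, no measured step of this kind exists among the three compounds, so no direction beyond the scatter is expected in this assay. Compound 4 is therefore estimated at 900 nM, between 300 nM and 3000 nM. The step from compound 3 to compound 4 is expected to be a 1.2-fold higher number from compound 3 to compound 4 (0.07 log units; within the scatter).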

Compound 4, half-maximal inhibitory concentration: 150 nM
Compound 4: the middle estimate sits 6.0-fold (0.78 log units) above what was measured, outside the stated range (below it).
By their numbers in this assay, from the lowest: compound 4; then compounds 3 and 2 (each within the scatter of the next). At a limit, above all of these: compound 1.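

In this assay, the group on a saturated chain carbon, four bonds along the chain from an amine nitrogen in a ring, proves able to move the number: 4-fluoro-1H-indol-1-yl in place of 5,6-dimethyl-1H-benzimidazol-1-yl gives a 5.1-fold lower number from compound 3 to compound 4 (0.71 log units; beyond the scatter). This is the only step shown between compounds differing in one place, so the earlier compounds could not show this sensitivity. No measurement shown accounts for the step.

Going by these compounds, the change swaps the ring nitrogen, the fluorine and both methyl groups at once, so it remains open which of these carries the step. Also open, on these data alone, is how a chlorine or a methoxy group in place of the fluorine, or a longer chain, would read.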